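A few compounds are considered here, and "the series" means these few. Any claim that something is new, unique, unknown or untested is made for them only; others in the source may bear on it.

In a physicochemical assay for lipophilicity, read by HPLC (on this read-out higher numbers stand for higher lipophilicity and lower numbers for lower lipophilicity), compound 1 `Nc1ccccc1NC(=O)c1ccc(CNC2=NC(c3ccc(F)cc3)CO2)cc1` gives 3.39 and compound 2 `Nc1ccccc1NC(=O)c1ccc(CNC2=NC(c3cccc(F)c3)CO2)cc1` gives 3.42, so the two stand level within the scatter. Compound 3 `Nc1ccccc1NC(=O)c1ccc(CNC2=NC(c3ccc(C(F)(F)F)cc3)CO2)cc1` differs from compound 2 as follows: 4-(trifluoromethyl)phenyl in place of 3-fluorophenyl on a saturated ring carbon. That is 4-(trifluoromethyl)phenyl in place of 3-fluorophenyl on a saturated ring carbon. For the measured compounds named here, only one measured step bears on this: a number 0.03 log units higher from compound 1 to compound 2 (within the scatter), which swapped one fluorophenyl for the other and stayed within the scatter. Going by the values given here, no measured step tests a larger group, so the guide is weak. The entering group counts more carbon and fluorine, so an upward step is expected in this assay, estimated as a number 0.53 log units higher from compound 2 to compound 3 (beyond the scatter). For compound 3 the estimated value is 3.95, within a range of 3.6 to 4.3.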

Compound 3, distribution coefficient: 4.54
Estimate against measurement, compound 3: 0.59 log units below; the measured number lies above the stated range.
By their numbers in this assay, from the lowest: compounds 1 and 2 (each within the scatter of the next); then compound 3.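

In this assay, the aryl group on this saturated ring carbon can shift the reading strongly, not just within the scatter as the swap between the two fluorophenyl groups did. Replacing 3-fluorophenyl with 4-(trifluoromethyl)phenyl gives a number 1.12 log units higher from compound 2 to compound 3 (beyond the scatter), and trifluoromethyl in place of fluoro on an aromatic carbon gives a number 1.15 log units higher from compound 1 to compound 3 (beyond the scatter), so a single group change on the aromatic ring is enough for a large step. No measurement shown here explains the size of this rise.

As far as these compounds go, it remains open whether a methyl group or a chlorine atom in place of the trifluoromethyl would give a step of similar size. An amine or a carboxylic acid on the same aromatic ring could also move the reading either way.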